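Acetamido for Propanoyloxy on a Coumarin-Free Shared Core

The source may hold more compounds than are shown below. What is called first, only, known or untested is meant among the compounds shown, and "the series" means these compounds.

Of the compounds shown here, two have been measured in a functional assay on HT-1080 cells (Homo sapiens), read by transwell migration, with a stated time of 24 h, tested at 1 uM; a lower number here means a stronger effect, a higher number a weaker effect of the compound at the concentration tested. Compound 1, `CCC(=O)OCc1ccc2oc(=O)c(C(=O)Oc3cccc(Br)c3)cc2c1`, gives 40.2% in this assay, the lowest of the two numbers. Compound 2, `O=C(Oc1ccccc1)c1cc2cc([N+](=O)[O-])ccc2oc1=O`, gives 76.7% in this assay, a value that lies well beyond the scatter above that of compound 1; the two differ in several places at once, so their gap cannot be tied to any one change.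

Compound 3, `CC(=O)NCc1ccc2oc(=O)c(C(=O)Oc3cccc(Br)c3)cc2c1`, has not yet been measured. It differs from compound 1 in a single place: acetamido in place of propanoyloxy on a saturated chain carbon bound to an aromatic carbon. Within the data shown here, no pair of measured compounds shows this change, so its effect in this assay can only be expected, not read off. The account expects the step from compound 1 to compound 3, a number 7.8 percentage points higher from compound 1 to compound 3 (within the scatter), to be small, perhaps within the scatter, with a slight lean toward a weaker effect. On that basis compound 3 is estimated to give 48% in this assay, with a plausible range from 30% to 70%.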

Compound 3, a percentage reported as activity, at one concentration (the size of the read-out at that concentration, not a potency): 36.9%
Beside the measured number, compound 3's estimate is 11.1 percentage points above it; low and high end bracket the measured number.
By their numbers in this assay, from the lowest: compounds 3 and 1 (each within the scatter of the next); then compound 2.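

In this assay, among these compounds, acetamido in place of propanoyloxy on a saturated chain carbon bound to an aromatic carbon gives a number 3.3 percentage points lower from compound 1 to compound 3 (within the scatter), the first comparison in this set that can be tied to a single place. The two groups differ in their atoms and in their hydrogen-bond donors and acceptors, yet compounds 1 and 3 read alike within the scatter, so the propanoyloxy group is not needed at this place to keep the read-out at the level of compound 1. No measurement shown speaks to why the two groups read alike.

As far as these compounds go, whether an amine, a carboxylic acid or a longer chain such as butanamido at the same place would also keep the read-out at this level remains open, since only these two groups have been compared there. Compound 2 still differs from compounds 1 and 3 in several places at once, so it remains unclear which of those places accounts for its higher number, and a reading at one concentration leaves potency itself unsettled.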